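The source may report more compounds than this note shows. Statements on the series, on what has been measured and on what is new or still open speak of the compounds shown alone.

Compounds measured in a functional assay on A549 cells (Homo sapiens) for antiproliferative activity, read by MTT assay, with a stated time of 24 h; a higher number here means a weaker inhibitor, a lower number a stronger inhibitor:
compound 1 `COc1ccc(-c2cc(/C=C/C(=O)c3cc(OC)c(OC)c(OC)c3)nc3cc(-c4ccccc4)nn23)cc1OC` — 7200 nM
compound 2 `COc1ccc(C(=O)/C=C/c2cc(-c3cc(OC)c(OC)c(OC)c3)n3nc(-c4ccccc4)cc3n2)cc1OC` — 17800 nM
compound 3 `COc1cc(-c2cc(/C=C/C(=O)c3ccc(C)c(C)c3)nc3cc(-c4ccccc4)nn23)cc(OC)c1OC` — 10600 nM

Compound 3 sits second highest of the three numbers; its nearest neighbour is compound 1 and its furthest compound 2, and both gaps fall within the scatter, so no order among the three can be read.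

Compound 4 `COc1cc(-c2cc(C(=O)/C=C/c3ccc(Cl)cc3)nc3cc(-c4ccccc4)nn23)cc(OC)c1OC` is the next compound: (2-(4-chlorophenyl)ethenyl)carbonyl in place of 2-((3,4-dimethylphenyl)carbonyl)ethenyl on an aromatic carbon.

For the measured compounds named here, only one measured step exists, a 1.7-fold lower number from compound 2 to compound 3 (0.23 log units; within the scatter), and it varies the aryl on the carbonyl carbon without leaving the scatter. Going by the values given here, no step covers a reversed enone or a 4-chlorophenyl, so there is nothing to suggest a direction; the expected step of a 1.1-fold lower number from compound 3 to compound 4 (0.03 log units; within the scatter) is none beyond the scatter. Compound 4 is estimated at 10000 nM, range 3000 nM to 35000 nM.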

Compound 4, half-maximal inhibitory concentration: 23800 nM
Estimate against measurement, compound 4: 2.4-fold (0.38 log units) below, and the stated range covers the measured number.
By their numbers in this assay, from the lowest: compounds 1, 3, 2 and 4 (each within the scatter of the next, the first and the last beyond it).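

In this assay, moving to the (2-(4-chlorophenyl)ethenyl)carbonyl group on the aromatic carbon next to the ring nitrogen gives a 2.2-fold higher number from compound 3 to compound 4 (0.35 log units; beyond the scatter) and is the first listed step beyond the scatter. This change reverses the chain, placing the carbonyl on the ring, and also replaces 3,4-dimethylphenyl with 4-chlorophenyl, so the step cannot be assigned to either part alone. No supporting evidence bears on this result.

Still open, on these data alone, is how each part acts alone, with the reversed chain carrying 3,4-dimethylphenyl and the original chain carrying 4-chlorophenyl. Also open, as far as these compounds go, is how a morpholine or a carboxylic acid on that aryl ring would read.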